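The compounds below may be only part of what the source reports. "The series", "measured", "known", "first", "only" and "open" are said of these compounds alone.

Measured compounds in this series:
- compound 1 `COC(=O)[C@@]1(C)CCC=C2[C@@H]1CC[C@@H](C)[C@]2(C)Cc1c[nH]c2ccc(Cl)cc12`: 11000 nM
- compound 2 `COC(=O)[C@@]1(C)CCC=C2[C@@H]1CC[C@@H](C)[C@]2(C)Cc1c[nH]c2ccc(F)cc12`: 7300 nM

In a functional assay on SW1573 cells (Homo sapiens) for inhibition, read by sulforhodamine B assay, with a stated time of 48 h (a higher number here means a weaker inhibitor of growth, a lower number a stronger inhibitor of growth), compound 2 holds the lowest of the two numbers; its nearest neighbour is compound 1, and the step of a 1.5-fold lower number from compound 1 to compound 2 (0.18 log units; within the scatter) lies within the scatter. Compound 3 `COC(=O)[C@@]1(C)CCC=C2[C@@H]1CC[C@@H](C)[C@]2(C)Cc1c(C)[nH]c2ccc(F)cc12` differs from compound 2 by methyl in place of hydrogen on an aromatic carbon. Among the compounds with values here, no measured step touches this part of the molecule; the single step on record, a 1.5-fold lower number from compound 1 to compound 2 (0.18 log units; within the scatter), concerns the halogen only and was itself within the scatter. Nothing in the data therefore points to a shift beyond the scatter for compound 3. Compound 3 is estimated at 6500 nM, range 2500 nM to 16000 nM. The expected step is a 1.1-fold lower number from compound 2 to compound 3 (0.05 log units; within the scatter).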

Compound 3, concentration for 50% growth inhibition: 12000 nM
Compound 3: middle estimate off by 1.8-fold (0.27 log units), on the low side; low and high end bracket the measured number.
By their numbers in this assay, from the lowest: compounds 2, 1 and 3 (each within the scatter of the next).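

In this assay, methyl in place of hydrogen on the aromatic carbon next to the ring nitrogen gives a 1.6-fold higher number from compound 2 to compound 3 (0.22 log units; within the scatter). This position of the five-membered aromatic ring therefore takes a methyl without a step beyond the scatter, which the halogen step alone could not show. No supporting data bear on this result.

On these data alone, whether an ethyl, a phenyl or an amine at this position would give a step beyond the scatter remains open. Also open, as far as these compounds go, is whether the methyl would read the same with chloro in place of fluoro.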